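Moving one methyl group in a cytotoxicity test

A few compounds are considered here, and "the series" means these few. Any claim that something is new, unique, unknown or untested is made for them only; others in the source may bear on it.

Of the compounds shown here, three with a shared core have been tested in an ADME assay on HEK293 cells (Homo sapiens) for cytotoxicity, read by ATP content, with a stated time of 6 h; on this read-out lower numbers stand for higher toxicity in this test and higher numbers for lower toxicity in this test. Compound 1 (`COCCCNc1nc(N)nc2ccn(Cc3ccccn3)c12`) gives > 24000 nM as a limit and not a number. Compound 2 (`Nc1nc(NCc2ncco2)c2c(ccn2Cc2ccccn2)n1`) gives > 24000 nM as a limit too. Compound 3 (`Cc1cnc(CNc2nc(N)nc3ccn(Cc4ccccn4)c23)o1`) gives > 24000 nM as a limit as well. So compound 3 has no exact value and stands with the others (the limit of > 24000 nM in this assay, at which 3 of the 3 values shown sit).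

Compound 4 (`Cc1coc(CNc2nc(N)nc3ccn(Cc4ccccn4)c23)n1`) has the same atoms as compound 3, joined differently (4-methyl-1,3-oxazol-2-yl in place of 5-methyl-1,3-oxazol-2-yl on a saturated chain carbon bound to a nitrogen on an aromatic ring). Here 4-methyl-1,3-oxazol-2-yl takes the place of 5-methyl-1,3-oxazol-2-yl.

The closest measured change is a step that the two limits leave unreadable from compound 2 to compound 3 where methyl replaces hydrogen on an aromatic carbon. The wider swaps, a step that the two limits leave unreadable from compound 1 to compound 2 and a step that the two limits leave unreadable from compound 1 to compound 3, also have no readable size. Going by the values given here, with no measured step to suggest otherwise, the expected result is a step that the limit leaves unreadable from compound 3 to compound 4 with no step beyond the scatter and no favoured direction. A report of only a limit is again expected. Compound 4 is estimated at 30000 nM with an expected range from 14000 nM to 60000 nM in this assay as a rough guide.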

Compound 4, half-maximal cytotoxic concentration: > 24000 nM
Compound 4: a limit, no number; the forecaster's own chance of this, stated with the estimate: 85%; the middle value does not contradict the limit.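

Compounds 1, 2, 3 and 4 each give only a limit, not a number, in this assay, so no step among them can be read: the limit of > 24000 nM in this assay, at which 4 of the 4 values shown sit.

The compounds shown leave open whether 4-methyl-1,3-oxazol-2-yl and 5-methyl-1,3-oxazol-2-yl differ at all on this read-out.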